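A few compounds are considered here, and "the series" means these few. Any claim that something is new, unique, unknown or untested is made for them only; others in the source may bear on it.

Compounds measured in a functional assay on CHO-K1 cells for agonist activity at Glucose-dependent insulinotropic receptor (Homo sapiens), read by cAMP accumulation and immunoassay, with a stated time of 1 h; on this read-out higher numbers stand for larger maximal responses and lower numbers for smaller maximal responses:

Compound 1, `COC(=O)N1CCC(Oc2ncnc(Oc3ccc(/C=C4\SC(=O)NC4=O)cc3)c2C)CC1`: compound 1 gives 53.3%
Compound 2, `CCOC(=O)N1CCC(Oc2ncnc(Oc3ccc(/C=C4\SC(=O)NC4=O)cc3)c2C)CC1`: compound 2 gives 141%
Compound 3, `COC(=O)N1CCC(Oc2cc(Oc3cccc(/C=C4\SC(=O)NC4=O)c3)ncn2)CC1`: compound 3 gives 33.7%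

Compound 2 differs from compound 1 by methyl in place of hydrogen on a saturated chain carbon bound to an oxygen next to a carbonyl group, and in this assay this step reads a number 87.7 percentage points higher from compound 1 to compound 2 (beyond the scatter). Compound 3 sits on a different core; how its core differs from that of compound 1 is not broken down here, and its maximal response is the lowest of the three measured values, beyond the scatter of either neighbour.

Compound 4, `CCOC(=O)N1CCC(Oc2cc(Oc3cccc(/C=C4\SC(=O)NC4=O)c3)ncn2)CC1`, is not yet measured. It differs from compound 3 by methyl in place of hydrogen on a saturated chain carbon bound to an oxygen next to a carbonyl group, the same kind of change as that from compound 1 to compound 2, made at the same kind of place. Because the step of a number 87.7 percentage points higher from compound 1 to compound 2 (beyond the scatter) was large, compound 4 is expected to rise well above compound 3, by an estimated a number 66.3 percentage points higher from compound 3 to compound 4 (beyond the scatter). The transfer is uncertain, since compound 3 starts from a lower value on a core whose behaviour is otherwise untested. Compound 4 is therefore estimated at 100%, within 55% to 150%.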

Compound 4, largest response reached (Emax), in percent of the reference or control that the assay uses: 43.3%
Estimate against measurement, compound 4: 56.7 percentage points above; the measured number lies below the stated range.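

In this assay, the change from methoxycarbonyl to ethoxycarbonyl on the core of compound 3 reads a number 9.6 percentage points higher from compound 3 to compound 4 (within the scatter), so compound 3 and compound 4 cannot be told apart on this read-out. The large step seen on the core of compound 1 therefore did not carry over to the core of compound 3, and the two steps differ in size: the same change on two cores in this assay, a number 87.7 percentage points higher (beyond the scatter) from compound 1 to compound 2 and a number 9.6 percentage points higher (within the scatter) from compound 3 to compound 4, 78.1 percentage points apart, beyond the scatter of two such steps. This shows that, in this series, the effect of the change depends on the core it is made on, but with one pair per core it does not show which feature of the two cores goes with the gap, nor how the change would read on any third core.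

The compounds shown leave open whether a longer chain, such as propoxycarbonyl in place of ethoxycarbonyl, would raise the maximal response on the core of compound 3. They also leave open whether such a chain would behave on the core of compound 1 as ethoxycarbonyl does there.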